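The source may hold more compounds than are shown below. What is called first, only, known or untested is meant among the compounds shown, and "the series" means these compounds.

Measured so far:
- compound 1 `c1ccc2c(-c3nnc(-c4ccncc4)o3)c[nH]c2c1`: 4100 nM
- compound 2 `COc1ccc(-c2nnc(-c3c[nH]c4ccccc34)o2)cc1`: > 1000000 nM

Within the data shown here, in a functional assay on PC-3 cells (Homo sapiens) for cytotoxicity, read by MTT assay (on this read-out lower numbers stand for stronger inhibition and higher numbers for weaker inhibition), compound 1 gives 4100 nM, the only firm number in this small set. Compound 2 reaches only a limit of this assay, > 1000000 nM, recorded as the limit of > 1000000 nM in this assay, at which 1 of the 2 values shown sits. Compound 3 `Clc1ccc(-c2nnc(-c3c[nH]c4ccccc34)o2)cc1` is not yet measured. It differs from compound 1 by 4-chlorophenyl in place of pyridin-4-yl on an aromatic carbon. Among the measured compounds shown here, no measured pair shows this exact step, so the direction rests on compound 2, whose limit sits at the limit of > 1000000 nM in this assay, at which 1 of the 2 values shown sits. A weakening step is expected, a 7.3-fold higher number from compound 1 to compound 3 (0.86 log units; beyond the scatter). Compound 3 is estimated at 30000 nM, between 5000 nM and 300000 nM.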

Compound 3, half-maximal inhibitory concentration: 41600 nM
Beside the measured number, compound 3's estimate is 1.4-fold (0.14 log units) below it, and the stated range covers the measured number.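

In this assay, the group at this position clearly matters: replacing pyridin-4-yl with 4-chlorophenyl gives a 10-fold higher number from compound 1 to compound 3 (1.01 log units; beyond the scatter). On the phenyl ring, replacing methoxy with chloro gives an at least 24-fold lower number from compound 2 to compound 3 (1.38 log units; beyond the scatter), so a single substituent there also changes the read-out strongly. That second step is open-ended, since compound 2 has a limit and not a number: the limit of > 1000000 nM in this assay, at which 1 of the 3 values shown sits.

On these data alone, the step from pyridin-4-yl to 4-chlorophenyl changes both the ring nitrogen and the chlorine, so the share of each remains unknown. Plain phenyl would separate them, and an amine or a carboxylic acid on that ring remains an open case.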